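The compounds below may be only part of what the source reports. "The series", "measured", "known", "first", "only" and "open" are said of these compounds alone.

Measured in a functional assay on A-375 cells (Homo sapiens) for cytotoxicity, read by MTT assay, with a stated time of 48 h; a higher number here means a weaker inhibitor, a lower number a stronger inhibitor:
- compound 1 `CC1(C)S[C@@H]2/C(=C\C(=O)c3ccc(C(F)(F)F)cc3)C(=O)N2[C@H]1C(=O)OC(c1ccccc1)c1ccccc1`: 26700 nM
- compound 2 `CC1(C)S[C@@H]2/C(=C\C(=O)OCc3ccccc3)C(=O)N2[C@H]1C(=O)OC(c1ccccc1)c1ccccc1`: 7100 nM
- compound 3 `CC1(C)S[C@@H]2/C(=C\C(=O)c3ccccc3)C(=O)N2[C@H]1C(=O)OC(c1ccccc1)c1ccccc1`: 22800 nM

Compound 3 gives the second highest of the three numbers in this assay. It sits closest to compound 1, the step of a 1.2-fold lower number from compound 1 to compound 3 (0.07 log units; within the scatter) being within the scatter, and furthest from compound 2, the step of a 3.2-fold higher number from compound 2 to compound 3 (0.51 log units; beyond the scatter) lying beyond it.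

Compound 4 `COC(=O)/C=C1/C(=O)N2[C@@H]1SC(C)(C)[C@@H]2C(=O)OC(c1ccccc1)c1ccccc1` differs from compound 3 in one place: methoxy in place of phenyl on a carbonyl carbon. The step that bears on this is a 3.2-fold higher number from compound 2 to compound 3 (0.51 log units; beyond the scatter), where an aryl ketone replaced a benzyl ester on the same carbonyl carbon; the reverse, from ketone to ester, is the direction taken here. The step of a 3.8-fold lower number from compound 1 to compound 2 (0.58 log units; beyond the scatter) points the same way. Whether a methoxy matches a benzyloxy is not shown by any measured pair, so the size is uncertain, but a modest lowering of the number, of the order seen in a 3.2-fold higher number from compound 2 to compound 3 (0.51 log units; beyond the scatter), is expected.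

Compound 4 is therefore estimated at 10000 nM in this assay, within 4000 nM to 25000 nM, an expected step of a 2.3-fold lower number from compound 3 to compound 4 (0.36 log units; beyond the scatter).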

Compound 4, half-maximal inhibitory concentration: 24600 nM
Compound 4: middle estimate off by 2.5-fold (0.39 log units), on the low side; the measured number falls inside the stated range.
By their numbers in this assay, from the lowest: compound 2; then compounds 3, 4 and 1 (each within the scatter of the next).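

In this assay the methoxycarbonyl group does not separate from the benzoyl group (a 1.1-fold higher number from compound 3 to compound 4 (0.03 log units; within the scatter)), nor from the ketone carrying 4-(trifluoromethyl)phenyl (a 1.1-fold lower number from compound 1 to compound 4 (0.04 log units; within the scatter)). An ester at this carbonyl carbon is thus not enough for the lower number of compound 2, and among these compounds that number goes with the phenyl of the benzyloxy group, whose replacement by hydrogen gives a step beyond the scatter (a 3.5-fold higher number from compound 2 to compound 4 (0.54 log units; beyond the scatter)). Nothing measured here accounts for this link.

Open, going by these compounds, is whether that phenyl must stay on an ester, as a benzylamino group on the same carbonyl carbon would test. Also open, on these data alone, is how a phenethyloxy group, with its longer chain, or a carboxylic acid at this carbon would read.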